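Swapping cyclopentyl for pyrrolyl on a weak compound

The compounds below may be only part of what the source reports. "The series", "measured", "known", "first", "only" and "open" are said of these compounds alone.

Measured so far:
compound 1 `COC(=O)c1nc(C2CCCC2)n(-c2ccc(F)cc2)n1`: 9550 nM
compound 2 `COC(=O)c1nc(-c2ccoc2)n(-c2ccc(F)cc2)n1`: 9320 nM
compound 3 `COC(=O)c1nc(C2CCCC2)n(-c2ccc(C(F)(F)F)cc2)n1`: > 100000 nM

In a functional assay on Jurkat cells (Homo sapiens) for inhibition, read by MTT assay, with a stated time of 72 h (on this read-out higher numbers stand for weaker inhibition of growth and lower numbers for stronger inhibition of growth), compound 1 gives 9550 nM and compound 2 gives 9320 nM; the step of a 1.0-fold lower number from compound 1 to compound 2 (0.01 log units; within the scatter) is within the scatter. For compound 3 only a limit is reported, > 100000 nM, which is not a number but the edge of the assay, and (the limit of > 100000 nM in this assay, at which 1 of the 3 values shown sits). The step of an at least 10-fold higher number from compound 1 to compound 3 (1.01 log units; beyond the scatter) is large. So compound 3 stands at the weak end of what this assay can show.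

Compound 4 `COC(=O)c1nc(-c2ccc[nH]2)n(-c2ccc(C(F)(F)F)cc2)n1` differs from compound 3 in one place: 1H-pyrrol-2-yl in place of cyclopentyl on an aromatic carbon. Within the data shown here, the only measured step that bears on this kind of change is the one from compound 1 to compound 2, where a five-membered aromatic ring replaced cyclopentyl and the number hardly moved. A similarly small shift is therefore expected here, so the step that the limit leaves unreadable from compound 3 to compound 4 is expected to stay within the scatter. Compound 4 is thus expected to give about 150000 nM, in the range 50000 nM to 500000 nM, and will most likely again be reported only as a limit.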

Compound 4, concentration for 50% growth inhibition: > 100000 nM
Compound 4: a limit, no number; the forecaster's own chance of this, stated with the estimate: 70%; the middle value is on the limit's open side.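

Compound 3 and compound 4 both stop at a limit rather than a number, so no step between them can be read: the limit of > 100000 nM in this assay, at which 2 of the 4 values shown sit.

As far as these compounds go, whether 1H-pyrrol-2-yl in place of cyclopentyl changes growth inhibition at all stays open, as does how far beyond the limit either compound lies.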